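From compound 2 to compound 3: adding a sulfanyl group

The source may hold more compounds than are shown below. What is called first, only, known or untested is meant among the compounds shown, and "the series" means these compounds.

Measured in a toxicity assay on GES1 cells (Homo sapiens) for inhibition, read by MTT assay, with a stated time of 72 h; a higher number here means a weaker inhibitor, a lower number a stronger inhibitor:
- Compound 1 `Cc1cc(N2CC[C@@H](C)[C@@H](N(C)c3ncnc4[nH]ccc34)C2)n2nc(SCc3ccc(Cl)cc3)nc2n1`: > 100000 nM (a limit of the assay)
- Compound 2 `Cc1cc(N2CC[C@@H](C)[C@@H](N(C)c3ncnc4[nH]ccc34)C2)n2ncnc2n1`: 57900 nM

Among the compounds with values here, compound 2 gives the only exact number so far, 57900 nM. For compound 1 there is only (the limit of > 100000 nM in this assay, at which 1 of the 2 values shown sits).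

The next molecule, compound 3 `Cc1cc(N2CC[C@@H](C)[C@@H](N(C)c3ncnc4[nH]ccc34)C2)n2nc(SCC3CC3)nc2n1`, keeps the shared core of compound 2 but has (cyclopropylmethyl)sulfanyl in place of hydrogen on an aromatic carbon.

Within the data shown here, only one measured step bears on this change. Putting hydrogen in place of (4-chlorobenzyl)sulfanyl on an aromatic carbon gave an at least 1.7-fold lower number from compound 1 to compound 2 (0.23 log units; that floor lies within the scatter). This is a weak guide, since its floor does not clear the scatter. Read in reverse, it leaves open either no change or a higher number when a sulfanyl group enters. A small move towards a higher number in this assay is therefore expected, perhaps no larger than the scatter.

The estimated change is a 1.3-fold higher number from compound 2 to compound 3 (0.11 log units; within the scatter). For compound 3 the expected value is 75000 nM, with an estimated range from 30000 nM to 130000 nM.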

Compound 3, half-maximal inhibitory concentration: 27900 nM
Beside the measured number, compound 3's estimate is 2.7-fold (0.43 log units) above it; measured number below the stated range.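

In this assay, the new result shows that a sulfanyl group on this aromatic carbon, between two ring nitrogen atoms, does not have to leave the number unchanged or raise it: (cyclopropylmethyl)sulfanyl in place of hydrogen gives a 2.1-fold lower number from compound 2 to compound 3 (0.32 log units; beyond the scatter). What the sulfur carries also matters, as cyclopropyl in place of 4-chlorophenyl on the saturated chain carbon bound to the sulfur gives an at least 3.5-fold lower number from compound 1 to compound 3 (0.55 log units; beyond the scatter). The true size of this second step cannot be read, since compound 1 has only a limit and not an exact number: the limit of > 100000 nM in this assay, at which 1 of the 3 values shown sits.

Going by these compounds, with a single exact sulfanyl example, it remains open whether the lower number in this assay depends on the sulfur, the cyclopropyl ring, or the chain as a whole. The compounds shown also leave open how a methylsulfanyl group, an amine, or a longer unbranched carbon chain on this same aromatic carbon would read, so no trend can yet be drawn for this position.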